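Indole-to-tolyl swap at the benzylic position: lipophilicity note

A few compounds are considered here, and "the series" means these few. Any claim that something is new, unique, unknown or untested is made for them only; others in the source may bear on it.

Of the compounds shown here, three have been measured in a physicochemical assay for lipophilicity, at pH 7.4; a lower number here means a more polar compound, a higher number a more lipophilic compound. Compound 1 `CNC(=O)c1cc(C(=O)NC2CCC2)cn(Cc2cccc(NC)c2)c1=O` gives 3.6. Compound 2 `CNC(=O)c1cc(C(=O)NC2CC2)cn(Cc2cccc3[nH]ccc23)c1=O` gives 2.9. Compound 3 `CNC(=O)c1ccc(=O)n(Cc2ccccc2)c1` gives 1.6. On these numbers compound 2 stands second highest of the three. Compound 1 sits above it by a margin beyond the usual scatter, and compound 3 sits well below it, again beyond the scatter.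

Compound 4 `CNC(=O)c1cc(C(=O)NC2CC2)cn(Cc2cccc(C)c2)c1=O` has not yet been measured in this assay. It differs from compound 2 in one place only: 3-methylphenyl in place of 1H-indol-4-yl on a saturated chain carbon bound to an aromatic nitrogen. The group that leaves carries 1 hydrogen-bond donor, the group that enters carries none.

Among the compounds with values here, no step between measured compounds isolates this change. A step upward in this assay that is clearly beyond the scatter is expected, though smaller than the gap from compound 2 up to compound 1, since compound 1 with 3.6 is taken as an upper reference. The expected step is a number 0.60 log units higher from compound 2 to compound 4 (beyond the scatter). For compound 4 the estimate is 3.5, within a range from 3 to 4.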

Compound 4, distribution coefficient: 3.6
The estimate for compound 4 lay 0.10 log units below the measured number, and the stated range covers the measured number.
By their numbers in this assay, from the lowest: compound 3; then compound 2; then compounds 1 and 4 (each within the scatter of the next).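

In this assay this position now has its first step that isolates a single change: 3-methylphenyl in place of 1H-indol-4-yl on a saturated chain carbon bound to an aromatic nitrogen gives a number 0.70 log units higher from compound 2 to compound 4 (beyond the scatter), with the rest of the structure held fixed. The earlier compounds shown here differ in more than one place, so they could not tie any difference to this group alone. The change also alters the ring set, the heavy-atom count and the hydrogen-bond donor count together, and nothing measured here separates these or explains the step.

From the compounds shown here alone, whether a 3-hydroxyphenyl or 3-carboxyphenyl group at this place would read closer to compound 2 or to compound 4 remains open. So does whether the step holds with another amide substituent in place of cyclopropyl.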